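Carboxymethyl on the ring nitrogen in a cell growth assay

The source may hold more compounds than are shown below. What is called first, only, known or untested is meant among the compounds shown, and "the series" means these compounds.

Compound 1 `O=C1NC(=S)S/C1=C\C1=Cc2ccccc2OC1` and compound 2 `O=C(O)CN1C(=O)/C(=C/C2=Cc3ccccc3OC2)SC1=S` share a core. In a functional assay on A549 cells (Homo sapiens) for antiproliferative activity, read by MTT assay, with a stated time of 72 h (on this read-out higher numbers stand for weaker inhibition and lower numbers for stronger inhibition), compound 1 gives 73100 nM. For compound 2 the assay gives only a limit, > 100000 nM. The step between them is therefore an at least 1.3-fold higher number from compound 1 to compound 2 (0.13 log units; that floor lies within the scatter), a change that is carboxymethyl in place of hydrogen on an amide-type nitrogen in a ring, and its floor comes from the limit of > 100000 nM in this assay, at which 1 of the 3 values shown sits. Compound 3 `CC1Oc2ccc(Br)cc2C=C1/C=C1\SC(=S)NC1=O` has a different core; how its core differs from that of compound 1 is not broken down here. In this assay compound 3 gives 47500 nM. Compound 4 `CC1Oc2ccc(Br)cc2C=C1/C=C1\SC(=S)N(CC(=O)O)C1=O` carries the same change as compound 2, namely (carboxymethyl in place of hydrogen on an amide-type nitrogen in a ring). Compound 4 is expected to show a step of a 1.9-fold higher number from compound 3 to compound 4 (0.28 log units; within the scatter), resting on the step from compound 1 to compound 2 of an at least 1.3-fold higher number from compound 1 to compound 2 (0.13 log units; that floor lies within the scatter). Compound 4 is estimated at 90000 nM, between 45000 nM and 200000 nM.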

Compound 4, half-maximal inhibitory concentration: > 50000 nM
Compound 4: a limit, no number; the forecaster's own chance of this, stated with the estimate: 45%; the middle value lies beyond the limit too.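

Compound 4 gives only a limit in this assay, > 50000 nM. The new step is therefore a floor and not a measured size, an at least 1.0-fold higher number from compound 3 to compound 4 (0.02 log units; that floor lies within the scatter), and on each of the two cores the compound carrying carboxymethyl ends at a limit. Both floors lie within the scatter, so the series does not show that the change carries the same size from one core to the other, nor that its size differs: the same change on two cores in this assay, an at least 1.3-fold higher number (0.13 log units; that floor lies within the scatter) from compound 1 to compound 2 and an at least 1.0-fold higher number (0.02 log units; that floor lies within the scatter) from compound 3 to compound 4; the limit leaves it open whether they differ

As far as these compounds go, the true size of the change on either core stays open. So does how an amine or a plain methyl on the amide-type nitrogen in the ring would compare with hydrogen and carboxymethyl on these cores.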